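The source may hold more compounds than are shown below. What is called first, only, known or untested is meant among the compounds shown, and "the series" means these compounds.

Compound 3 `CC(C)n1nc(-c2ccc3oc(N)nc3c2)c2c(=O)[nH]c(N(C)C)nc21` stands lowest of the three solubility numbers gathered so far. In a physicochemical assay for solubility, read by HPLC, in phosphate buffer, measured as kinetic solubility, with a stated time of 24 h, at 20 degrees C, at pH 7.4, tested at 100 uM (a lower number here means a less soluble compound, a higher number a more soluble compound), compound 3 gives 2000 nM, whereas compound 2 `CC(C)n1nc(-c2ccc3oc(N)nc3c2)c2c(=O)[nH]c(N)nc21` gives 9200 nM and compound 1 `CC(C)n1nc(-c2ccc3oc(N)nc3c2)c2c(CO)nc(N)nc21` gives 82000 nM. Among the compounds with values here, only one measured step rests on a single change, and it moved the number downward: a 4.6-fold lower number from compound 2 to compound 3 (0.66 log units; beyond the scatter). Compound 4 `CC(C)n1nc(-c2ccc3oc(N)nc3c2)c2c(=O)[nH]cnc21` differs from compound 3 by hydrogen in place of dimethylamino on an aromatic carbon. Within the data shown here, no measured pair removes a group from that position outright, so the expectation leans on the downward move seen in a 4.6-fold lower number from compound 2 to compound 3 (0.66 log units; beyond the scatter) and reads it backwards, allowing a modest recovery when the dimethylamino is taken away. The expected step is a 2.5-fold higher number from compound 3 to compound 4 (0.40 log units; beyond the scatter). Compound 4 is accordingly estimated at 5000 nM, within a range from 1500 nM to 15000 nM.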

Compound 4, solubility: 3000 nM
Estimate against measurement, compound 4: 1.7-fold (0.22 log units) above, within the range that was stated.
By their numbers in this assay, from the lowest: compounds 3 and 4 (each within the scatter of the next); then compound 2; then compound 1.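

In this assay, hydrogen in place of dimethylamino on the aromatic carbon between two ring nitrogen atoms (a 1.5-fold higher number from compound 3 to compound 4 (0.18 log units; within the scatter)) leaves the two compounds indistinguishable. Hydrogen in place of amino (a 3.1-fold lower number from compound 2 to compound 4 (0.49 log units; beyond the scatter)) shows that, among these three groups, the higher number at this position belongs to amino alone and does not simply follow from the absence of dimethylamino. No measurement at hand explains this. Going by these compounds, whether methylamino sits with amino or with dimethylamino stays open, as does the outcome with a carboxylic acid or a longer chain here.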